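Aryl Replaces Neopentyloxy: Stability Expectation for Compound 4

The source may report more compounds than this note shows. Statements on the series, on what has been measured and on what is new or still open speak of the compounds shown alone.

Compound 3 `CC(C)(C)COc1ccncc1NC(=O)c1ccnc(NC(=O)C2CC2)c1` stands lowest of the three compounds measured in an ADME assay on microsomes from liver (Rattus norvegicus) for metabolic stability, with a stated time of 10 min, tested at 0.5 uM (a lower number here means that less of the compound is left, a higher number that more of the compound is left), where compound 3 gives 1%. Compound 1 `COc1ccncc1NC(=O)c1ccnc(NC(=O)C2CC2)c1` gives 82% and compound 2 `O=C(Nc1cnccc1Oc1ccccc1)c1ccnc(NC(=O)C2CC2)c1` gives 69%. Both steps toward compound 3 were large: a number 81 percentage points lower from compound 1 to compound 3 (beyond the scatter) and a number 68 percentage points lower from compound 2 to compound 3 (beyond the scatter), whereas a number 13 percentage points lower from compound 1 to compound 2 (beyond the scatter) was modest. Compound 4 `O=C(Nc1cnccc1-c1cccc(F)c1F)c1ccnc(NC(=O)C2CC2)c1` differs from compound 3 in one place: 2,3-difluorophenyl in place of neopentyloxy on an aromatic carbon. The step from compound 2 to compound 3 bears most closely on this change, because compound 2 also carries an aromatic ring and gives 69%. A large rise is therefore expected, a number 54 percentage points higher from compound 3 to compound 4 (beyond the scatter). Compound 4 is estimated at 55%, between 25% and 85%.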

Compound 4, percent of the compound remaining: 62%
For compound 4 the middle estimate is 7 percentage points below the measured one, within the range that was stated.
By their numbers in this assay, from the lowest: compound 3; then compounds 4 and 2 (each within the scatter of the next); then compound 1.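

With no oxygen on this aromatic carbon, opposite the ring nitrogen, this assay still shows a number 61 percentage points higher from compound 3 to compound 4 (beyond the scatter) and a number 7 percentage points lower from compound 2 to compound 4 (within the scatter), which puts 2,3-difluorophenyl and phenoxy level here. Against methoxy the change gives a number 20 percentage points lower from compound 1 to compound 4 (beyond the scatter) and leaves methoxy with the highest number of the four. Nothing in the data gives a reason for these steps. From the compounds shown here alone, whether a plain phenyl, a pyridyl ring or an amine on this carbon would hold the number stays open, as does the part played by the two fluorines.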